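The source may hold more compounds than are shown below. What is called first, only, known or untested is meant among the compounds shown, and "the series" means these compounds.

Working notes on the series in an ADME assay on RD cells (Homo sapiens) for cytotoxicity, read by MTT assay, with a stated time of 3 days; on this read-out lower numbers stand for higher toxicity in this test and higher numbers for lower toxicity in this test. Compound 1 (`CCC[C@@H](CCn1cncn1)c1ccc(Cl)cc1`) gives 40.8 ug/mL, compound 2 (`c1ccc(C[C@@H](CCn2cncn2)c2ccccc2)cc1`) gives 56 ug/mL, and compound 3 (`Clc1ccc([C@H](CCn2cncn2)Cc2ccccc2)cc1`) gives 21.7 ug/mL. Compound 3 cannot be told apart from compound 1, with a 1.9-fold lower number from compound 1 to compound 3 (0.27 log units; within the scatter). It separates only from compound 2, with a 2.6-fold lower number from compound 2 to compound 3 (0.41 log units; beyond the scatter).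

Compound 4 (`Clc1ccc([C@H](CCn2cncn2)Cc2ccccc2)c(Cl)c1`) differs from compound 3 by one change: chloro in place of hydrogen on an aromatic carbon. This is chloro in place of hydrogen on an aromatic carbon, ortho to a large group and meta to a chloro group. Among the compounds with values here, the one measured step of this kind is the modest one already seen, a 2.6-fold lower number from compound 2 to compound 3 (0.41 log units; beyond the scatter). The phenyl for ethyl step does not bear on this change. Within the data shown here, no measured step shows a chloro at this place, and a single pair is thin support, so a similar or somewhat smaller move toward lower numbers is expected, close to the scatter. The expected step is a 1.8-fold lower number from compound 3 to compound 4 (0.26 log units; within the scatter). For compound 4 the estimated value is 12 ug/mL, with an expected range of 6 ug/mL to 25 ug/mL.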

Compound 4, half-maximal cytotoxic concentration: 1.9 ug/mL
Compound 4: the middle estimate sits 6.3-fold (0.80 log units) above what was measured; measured number outside the range, below it.
By their numbers in this assay, from the lowest: compound 4; then compounds 3, 1 and 2 (each within the scatter of the next, the first and the last beyond it).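

In this assay, chloro in place of hydrogen on an aromatic carbon, ortho to a large group and meta to a chloro group, gives an 11-fold lower number from compound 3 to compound 4 (1.06 log units; beyond the scatter), a large step, whereas the earlier chloro step, a 2.6-fold lower number from compound 2 to compound 3 (0.41 log units; beyond the scatter), was modest. The same kind of change can therefore differ widely in size within this series, although the two pairs differ both in place and in whether a chloro group is already on the ring, and they cannot separate these two factors. Nothing available explains the larger step at this position.

Going by these compounds, whether the step belongs to chloro itself or would also follow a fluoro, methyl or methoxy group at this place remains open. Also open, on these data alone, is whether chloro at this place gives a similar step when the existing chloro group is replaced by hydrogen.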